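The source may hold more compounds than are shown below. What is called first, only, known or untested is meant among the compounds shown, and "the series" means these compounds.

Measured so far:
- compound 1 `C[C@H](Nc1nc(N)nc(N)c1C#N)c1cc2ccc(F)cn2c(=O)c1-c1ccccc1`: in an ADME assay on microsomes from liver (Mus musculus), read by LC-MS, using NADPH, with a stated time of 30 min, tested at 1 uM (a lower number here means that less of the compound is left, a higher number that more of the compound is left), compound 1 gives 42%.
- compound 2 `C[C@H](Nc1ccnc(N)n1)c1cc2ccc(F)cn2c(=O)c1-c1ccccc1`: in this assay compound 2 gives "not determined" (no result reported).
- compound 3 `Cc1nc(N)c(C#N)c(N[C@@H](C)c2cc3ccc(F)cn3c(=O)c2-c2ccccc2)n1`: in this assay compound 3 gives "not determined" (no result reported).

For the measured compounds named here, compound 1 holds the only number in this assay; compounds 2 and 3 carry no result, so nothing on the numbers can be compared and no step between measured compounds is available. Compound 4 `C[C@H](Nc1nc(N)nc(N)c1C#N)c1cc2ccc(F)cn2c(=O)c1-c1ccc(F)cc1` differs from compound 1 by fluoro in place of hydrogen on an aromatic carbon, para to a large group; read one bond further out, phenyl becomes 4-fluorophenyl. Going by the values given here, with no measured step to lean on, the expected step is a number 6 percentage points higher from compound 1 to compound 4 (within the scatter), a small shift not clearly beyond the scatter. Compound 4 is expected to give 48% in this assay, within 28% to 70%.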

Compound 4, percent of the compound remaining: 84%
Beside the measured number, compound 4's estimate is 36 percentage points below it; the measured number lies above the stated range.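

In this assay, phenyl to 4-fluorophenyl gives a number 42 percentage points higher from compound 1 to compound 4 (beyond the scatter), so this position, para to a large group, responds strongly to a change of a single heavy atom. For the compounds shown here, the earlier compounds offered no step, so this is the first sign that the phenyl group affects the percent remaining. From the compounds shown here alone, whether chloro, methoxy or an amine in the same place would give a similar number remains open, as does whether the step carries over to other substituents on the shared core. Nothing shown here explains the size of this step.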